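A few compounds are considered here, and "the series" means these few. Any claim that something is new, unique, unknown or untested is made for them only; others in the source may bear on it.

Within the data shown here, in a functional assay on RS4-11 cells (Homo sapiens) for inhibition, read by CCK-8 assay, with a stated time of 48 h (on this read-out lower numbers stand for stronger inhibition and higher numbers for weaker inhibition), compound 3 `O=[N+]([O-])c1cccc(NC(=S)NCCNS(=O)(=O)c2ccc(-c3ccccc3OCc3ccccc3)s2)c1` gives 11600 nM, the only true number so far. Compound 1 `COc1ccc(NC(=O)NCCNS(=O)(=O)c2ccc(-c3ccccc3OCc3ccccc3)s2)cc1` reaches only a limit, > 20000 nM. Compound 2 `O=S(=O)(NCCNC(=S)Nc1cccc(Cl)c1)c1ccc(-c2ccccc2OCc2ccccc2)s1` also gives only a limit, > 50000 nM. Compound 4 `O=C(NCCNS(=O)(=O)c1ccc(-c2ccccc2OCc2ccccc2)s1)Nc1cccc([N+](=O)[O-])c1` changes one group of compound 3: a group of 12 heavy atoms (7 carbon, 2 nitrogen, 3 oxygen; one six-membered aromatic ring of carbon only) in place of a group of 12 heavy atoms (7 carbon, 2 nitrogen, 2 oxygen, 1 sulfur; one six-membered aromatic ring of carbon only), on an amine nitrogen. In practice, a sulfur gives way to an oxygen. Among the measured compounds shown here, no measured pair isolates this swap. The closest guide is an at least 1.7-fold lower number from compound 1 to compound 3 (0.23 log units; that floor lies within the scatter), a step that also changes the substituent on the aromatic ring. Nitro in place of chloro gives an at least 4.3-fold lower number from compound 2 to compound 3 (0.63 log units; beyond the scatter), so compound 4 keeps the nitro group of the only compound with a true number. A modest weakening is therefore expected, an estimated 1.7-fold higher number from compound 3 to compound 4 (0.24 log units; within the scatter). For compound 4 the expected value is 20000 nM, with an estimated range of 8000 nM to 50000 nM.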

Compound 4, half-maximal inhibitory concentration: > 20000 nM
Compound 4: no number, only a limit (the forecaster's own chance of this, stated with the estimate: 45%); the middle value sits exactly at the limit.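

Among these compounds, compound 3 and compound 4 differ only by an oxygen in place of a sulfur, with the nitro group kept, and no other pair shows this change alone. The swap gives an at least 1.7-fold higher number from compound 3 to compound 4 (0.23 log units; that floor lies within the scatter), so this floor alone shows no real loss. In this assay compound 4 gives only a limit, > 20000 nM, and its steps to compound 1 and compound 2 cannot be read: the limit of > 20000 nM in this assay, at which 2 of the 4 values shown sit.

Going by these compounds, how far the true value of compound 4 lies past its limit stays open. Also open, on these data alone, is what a carboxylic acid in place of the nitro group would give.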